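The source may hold more compounds than are shown below. What is called first, only, known or untested is meant among the compounds shown, and "the series" means these compounds.

Among the compounds with values here, compound 1 `CC(C)CN1CCc2c(sc(NC(=O)Nc3ccc(Cl)cc3)c2C(N)=O)C1` is the single member of the set with a number in a functional assay (strain AB) with Danio rerio as the target, read by microscopy, with a stated time of 1 h (on this read-out lower numbers stand for an effect already at smaller amounts and higher numbers for an effect only at larger amounts of compound), where compound 1 gives 4510 nM. Compound 2 `CCC(O)c1cc2c(cc1NC(=O)Nc1ccc(Cl)cc1)OCCO2` reaches only the limit of > 25000 nM in this assay. Compound 3 `CCN1CCc2c(sc(NC(=O)Nc3ccc(Cl)cc3)c2C(=O)c2nnco2)C1` also stops at the limit of > 25000 nM in this assay; this is the limit of > 25000 nM in this assay, at which 2 of the 3 values shown sit. Compound 4 `CC(C)(C)OC(=O)CCCCCN1CCc2c(sc(NC(=O)Nc3ccc(Cl)cc3)c2C(N)=O)C1` has not yet been measured. It differs from compound 1 by 4-(tert-butoxycarbonyl)butyl in place of isopropyl on a saturated chain carbon bound to an amine nitrogen in a ring. Within the data shown here, no pair of measured compounds differing in one place is available, so the size of this step in this assay cannot be read from the measured compounds. The expectation for compound 4 in this assay is 6500 nM, within 1800 nM to 25000 nM, an estimated step of a 1.4-fold higher number from compound 1 to compound 4 (0.16 log units; within the scatter) expected to stay close to the scatter or drift toward the weaker side.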

Compound 4, half-maximal effective concentration: 620 nM
Estimate against measurement, compound 4: 10-fold (1.02 log units) above; the whole stated range lies above it.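

Replacing isopropyl with 4-(tert-butoxycarbonyl)butyl on a saturated chain carbon bound to an amine nitrogen in a ring gives, in this assay, a 7.3-fold lower number from compound 1 to compound 4 (0.86 log units; beyond the scatter). This position therefore accepts a much larger chain ending in tert-butoxycarbonyl, and the number falls rather than rises. Nothing measured here accounts for the step.

On these data alone, it remains open whether the chain length or the tert-butoxycarbonyl end drives this change. A plain alkyl chain of similar length, the free carboxylic acid or a terminal amine would separate these two contributions.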